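Dropping the Phenyl Group From Compound 1

The source may report more compounds than this note shows. Statements on the series, on what has been measured and on what is new or still open speak of the compounds shown alone.

The series shares one core, carried by compound 1 `COc1ccc(Cn2nc(-c3ccccc3)c3cc(C(=N)Nc4ccccc4)ncc32)cc1`. In a functional assay on PC-3 cells (Homo sapiens) for cytotoxicity, read by MTT assay, with a stated time of 72 h (on this read-out lower numbers stand for stronger inhibition and higher numbers for weaker inhibition), compound 1 gives 6300 nM, which places it second highest of the three measured numbers. Compound 2 `COc1ccc(Cn2nc(-c3ccccc3)c3cc(C(=N)Nc4ccccc4)nc(NC4CCCCC4)c32)cc1` carries an added cyclohexylamino group, and in this assay compound 2 gives 1100 nM; the step is a 5.7-fold lower number from compound 1 to compound 2 (0.76 log units; beyond the scatter). Compound 3 `N=C(Nc1ccccc1)c1cc2c(-c3ccccc3)n[nH]c2cn1` lacks the 4-methoxybenzyl group, and in this assay compound 3 gives 23000 nM; the step is a 3.7-fold higher number from compound 1 to compound 3 (0.56 log units; beyond the scatter).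

Compound 4 `COc1ccc(Cn2ncc3cc(C(=N)Nc4ccccc4)ncc32)cc1` differs from compound 1 in one place: hydrogen in place of phenyl on an aromatic carbon. Going by the values given here, no measured pair tests the removal of this phenyl group directly. The step from compound 1 to compound 3 is the closest guide, since there too a group was removed and the number rose beyond the scatter, while the step from compound 1 to compound 2 shows that adding a group lowered it. On that basis compound 4 is expected to show a modest rise, a 2.4-fold higher number from compound 1 to compound 4 (0.38 log units; beyond the scatter). Compound 4 is estimated at 15000 nM, with a range from 5000 nM to 50000 nM.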

Compound 4, half-maximal inhibitory concentration: 36000 nM
Compound 4: middle estimate off by 2.4-fold (0.38 log units), on the low side; the range from low to high includes it.
By their numbers in this assay, from the lowest: compound 2; then compound 1; then compounds 3 and 4 (each within the scatter of the next).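

Taking the phenyl away gives a 5.7-fold higher number from compound 1 to compound 4 (0.76 log units; beyond the scatter) in this assay, so the group on this aromatic carbon of the five-membered ring contributes to the activity of the shared core. Compounds 1, 2 and 3 all carry this phenyl, so they could not show this; compound 4 now shows that the number of compound 1 depends on the phenyl as well as on the 4-methoxybenzyl group. Nothing available explains why the phenyl matters at this position.

The compounds shown leave open whether a ring is needed here at all, or whether a methyl group, a cyclohexyl ring or a pyridine ring on this carbon would do as well as phenyl. They also leave open whether removing the phenyl would have a similar effect on compound 2, which carries the cyclohexylamino group.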